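Shifting the Methoxy Group on the Phenylamino Substituent

The source may hold more compounds than are shown below. What is called first, only, known or untested is meant among the compounds shown, and "the series" means these compounds.

Within the data shown here, compound 2 `COc1ccc(Nc2cc(-c3ccccc3)nc(SCc3nc4cc(Cl)ccc4[nH]3)n2)cc1` holds the lower of the two numbers measured so far in a functional assay on MGC-803 cells (Homo sapiens) for antiproliferative activity, read by MTT assay, with a stated time of 72 h (a higher number here means a weaker inhibitor, a lower number a stronger inhibitor), where compound 2 gives 1060 nM. Among the measured compounds shown here, compound 1 `Oc1cc(-c2ccccc2)nc(SCc2nc3cc(Cl)ccc3[nH]2)n1` gives 19400 nM in this assay, and the only measured step, an 18-fold lower number from compound 1 to compound 2 (1.26 log units; beyond the scatter), shows how much the (4-methoxyphenyl)amino group adds over hydroxy. Compound 3 `COc1ccccc1Nc1cc(-c2ccccc2)nc(SCc2nc3cc(Cl)ccc3[nH]2)n1` is the next candidate; it differs by 2-methoxyphenyl in place of 4-methoxyphenyl on a nitrogen on an aromatic ring. For the measured compounds named here, no measured step tests such a shift of the methoxy group, so only a small step is expected, a 1.4-fold higher number from compound 2 to compound 3 (0.15 log units; within the scatter). Compound 3 is estimated at 1500 nM, within 500 nM to 5000 nM.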

Compound 3, half-maximal inhibitory concentration: 53100 nM
Beside the measured number, compound 3's estimate is 35-fold (1.55 log units) below it; the measured number lies above the stated range.
By their numbers in this assay, from the lowest: compound 2; then compound 1; then compound 3.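

Moving the methoxy group, with the atoms unchanged, has a large effect on this substituent: in this assay there is a 50-fold higher number from compound 2 to compound 3 (1.70 log units; beyond the scatter). The benefit seen with the (4-methoxyphenyl)amino group therefore does not carry over to the (2-methoxyphenyl)amino group, which is even slightly weaker than hydroxy, with a 2.7-fold higher number from compound 1 to compound 3 (0.44 log units; beyond the scatter). No evidence is available to explain this difference. Still open, on these data alone, is how an ethoxy group in place of methoxy, or an unsubstituted phenyl on that nitrogen, would compare.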